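Phenethyl chain, sulfur acids, and where lipophilicity lands

The source may hold more compounds than are shown below. What is called first, only, known or untested is meant among the compounds shown, and "the series" means these compounds.

Three compounds sit on the same measure. In a physicochemical assay for lipophilicity, read by LC-MS, using the shake flask method, with a stated time of 1 h, at pH 7.4 (on this read-out higher numbers stand for higher lipophilicity and lower numbers for lower lipophilicity), compound 1, with the structure `O=C1NC(=O)C(Cc2ccccc2)S1`, gives 1.07. Compound 2, with the structure `O=S(=O)(Cc1ccccc1)c1ccccc1O`, gives 1.76 in this assay. Compound 3, with the structure `O=S(O)CCc1ccccc1`, gives -1.3 in this assay, the lowest of the three numbers: compound 1 stands a good way higher, beyond the scatter, and compound 2 further still, also beyond the scatter. No two of these compounds differ in just one place, so the individual numbers are all that can be read from them.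

Compound 4, with the structure `O=S(=O)(O)CCc1ccccc1`, has not yet been measured. It differs from compound 3 in one place: sulfo in place of hydroxysulfinyl on a saturated chain carbon, two bonds along the chain from an aromatic carbon. Among the measured compounds shown here, no measured pair shows what this exchange does to the read-out, so the expectation rests on the starting number alone. Since compound 3 already gives -1.3, compound 4 is expected to sit lower still, with a step of a number 0.70 log units lower from compound 3 to compound 4 (beyond the scatter) in this assay, beyond the scatter but uncertain in size. The estimate for compound 4 is -2, with a range from -3 to -1 in this assay.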

Compound 4, distribution coefficient: -1.45
Compound 4: the middle estimate sits 0.55 log units below what was measured; the measured number falls inside the stated range.
By their numbers in this assay, from the lowest: compounds 4 and 3 (each within the scatter of the next); then compound 1; then compound 2.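

In this assay, putting sulfo in place of hydroxysulfinyl on a saturated chain carbon, two bonds along the chain from an aromatic carbon, amounts to a number 0.15 log units lower from compound 3 to compound 4 (within the scatter), so on this read-out the two groups cannot be told apart at this position. Among the compounds shown here, this is the first comparison here of two compounds that differ in one place, and it shows that the exchange, which brings one more oxygen, one more double bond outside aromatic rings and one more hydrogen-bond acceptor while keeping the single hydrogen-bond donor, leaves the number within the usual scatter of repeated measurements. Nothing given here explains this result.

The compounds shown leave open whether a carboxylic acid or an amine on the same saturated chain carbon would give a number close to those of this pair or a very different one. They also leave open whether a longer chain between the aromatic ring and the sulfur group would keep the two groups this close, since this single pair speaks only for the chain it carries.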